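A few compounds are considered here, and "the series" means these few. Any claim that something is new, unique, unknown or untested is made for them only; others in the source may bear on it.

For the measured compounds named here, compound 2 `COc1ccc(C(=O)Nc2c(C)cccc2Cl)cc1OC1CCCC1` is the only compound with a number in an assay on isolated protein for inhibition of phosphodiesterase 4A (Sus scrofa); on this read-out lower numbers stand for stronger inhibition and higher numbers for weaker inhibition: compound 2 gives 100 nM. Compound 1 `COc1ccc(C(=O)Nc2cccc(Cl)c2Cl)cc1OC1CCCC1` gives only a limit in this assay, > 200000 nM, and the comparison of these two rests on (the limit of > 200000 nM in this assay, at which 1 of the 2 values shown sits). Going by the values given here, the one measured step at the group on the amide-type nitrogen is an at least 2000-fold lower number from compound 1 to compound 2 (3.30 log units; beyond the scatter), so a change at this place can move the number a long way. Compound 3 `COc1ccc(C(=O)Nc2ccncc2Cl)cc1OC1CCCC1` differs from compound 2 by 3-chloropyridin-4-yl in place of 2-chloro-6-methylphenyl on an amide-type nitrogen. This step touches the same place as the measured one, but the measured step gives its size only for another pair of groups and no direction for this exchange. The number for compound 3 is therefore expected to stay near that of compound 2, with the step of a 1.3-fold lower number from compound 2 to compound 3 (0.10 log units; within the scatter) estimated to lie within the scatter, and compound 3 is estimated at 80 nM, in a range from 15 nM to 400 nM.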

Compound 3, half-maximal inhibitory concentration: 16 nM
The estimate for compound 3 lay 5.0-fold (0.70 log units) above the measured number; the range from low to high includes it.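

In this assay, the place on the amide-type nitrogen now has a step read between two real numbers, a 6.3-fold lower number from compound 2 to compound 3 (0.80 log units; beyond the scatter). It shows that a six-membered aromatic ring with a hetero atom is accepted here: 3-chloropyridin-4-yl, which counts one hydrogen-bond acceptor where 2-chloro-6-methylphenyl counts none, gives the lower number of the two. The other new step, an at least 12000-fold lower number from compound 1 to compound 3 (4.09 log units; beyond the scatter), starts from a limit and not from a number, so its full size cannot be read: the limit of > 200000 nM in this assay, at which 1 of the 3 values shown sits.

The compounds shown do not separate the ring nitrogen from the loss of the methyl group, as both change in the same step. Also open, going by these compounds, is what a 3,5-dichloropyridin-4-yl group, or a pyridine ring carrying an amine, would give at this place.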